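The source may hold more compounds than are shown below. What is called first, only, known or untested is meant among the compounds shown, and "the series" means these compounds.

Measured so far: compound 1 `NS(=O)(=O)c1ccc(C(=O)N/N=C(/CS(=O)(=O)c2ccccc2)c2ccc(Cl)cc2)cc1` gives 57000 nM; compound 2 `NS(=O)(=O)c1ccc(C(=O)N/N=C(/CS(=O)(=O)c2ccccc2)c2ccc(F)cc2)cc1` gives 620 nM; compound 3 `NS(=O)(=O)c1ccc(C(=O)N/N=C\c2ccc(Cl)cc2)cc1` gives 36700 nM, all in a functional assay on MCF7 cells (Homo sapiens) for antiproliferative activity, read by MTT assay; a higher number here means a weaker inhibitor, a lower number a stronger inhibitor.

The change from compound 1 to compound 2 is fluoro in place of chloro on an aromatic carbon. It produced a 92-fold lower number from compound 1 to compound 2 (1.96 log units; beyond the scatter). Compound 4 `NS(=O)(=O)c1ccc(C(=O)N/N=C\c2ccc(F)cc2)cc1` carries the same kind of change on the core of compound 3: fluoro in place of chloro on an aromatic carbon. The difference between the core of compound 1 and the core of compound 3 is not broken down here; in this assay compound 3 and compound 1 give numbers that lie within the scatter of each other.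

Among the compounds with values here, because only one earlier instance of this change exists and it produced a 92-fold lower number from compound 1 to compound 2 (1.96 log units; beyond the scatter) on a core whose difference from compound 3 is not resolved, the step is expected to be smaller than the earlier one: compound 4 is expected to show a 9.2-fold lower number from compound 3 to compound 4 (0.96 log units; beyond the scatter). Compound 4 is therefore estimated at 4000 nM, between 500 nM and 40000 nM.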

Compound 4, half-maximal inhibitory concentration: 9170 nM
The estimate for compound 4 lay 2.3-fold (0.36 log units) below the measured number; measured number inside the range.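

On the second core, the change from 4-chlorophenyl to 4-fluorophenyl again lowers the number in this assay, giving a 4.0-fold lower number from compound 3 to compound 4 (0.60 log units; beyond the scatter). The direction of the change carries over from one core to the other, but its size does not: the same change on two cores in this assay, a 92-fold lower number (1.96 log units; beyond the scatter) from compound 1 to compound 2 and a 4.0-fold lower number (0.60 log units; beyond the scatter) from compound 3 to compound 4, 23-fold (1.36 log units) apart, beyond the scatter of two such steps. These two pairs do not show what sets the steps apart, and the difference between the core of compound 1 and the core of compound 3 remains unresolved.

Going by these compounds, it remains open how either core responds when an unsubstituted phenyl, a methoxy group, a nitrile or an amine stands in the same place. Within the data shown here, with only two pairs, no general rule for this change can be drawn across the series.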